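The source may report more compounds than this note shows. Statements on the series, on what has been measured and on what is new or still open speak of the compounds shown alone.

Compound 1 `Nc1nc(O)c2c(n1)n(C1OC(CO)[C@@H](O)[C@H]1O)c(=O)n2Cc1ccc(Cl)c(Cl)c1` is measured in a functional assay on YAC-1 cells (Mus musculus) (a higher number here means a larger maximal response, a lower number a smaller maximal response), where compound 1 gives 15%. Two compounds with the same core are measured alongside it: compound 2 `C=CCn1c(=O)n([C@@H]2O[C@H](CO)[C@H]3OC(C)(CCC(=O)O)O[C@H]32)c2nc(N)nc(O)c21` gives 0%, and compound 3 `C=CCn1c(=O)n([C@@H]2O[C@H](CO)[C@H]3OC(C)(CCC(=O)NC)O[C@H]32)c2nc(N)nc(O)c21` gives 0%. Among these three numbers compound 1 stands highest, and its lead over compound 2 and over compound 3 lies beyond the scatter. Among the compounds with values here, the one step between measured compounds, no change at the digits printed from compound 2 to compound 3 (within the scatter), concerns methylamino in place of hydroxy on a carbonyl carbon and not the group on the saturated chain carbon bound to an aromatic nitrogen. Compound 4 `Nc1nc(O)c2c(n1)n(C1OC(CO)[C@@H](O)[C@H]1O)c(=O)n2Cc1ccc([N+](=O)[O-])cc1` differs from compound 1 by 4-nitrophenyl in place of 3,4-dichlorophenyl on a saturated chain carbon bound to an aromatic nitrogen. Within the data shown here, no measured step bears on this change. The expected step is a number 5 percentage points lower from compound 1 to compound 4 (within the scatter), within the scatter. Compound 4 is therefore estimated at 10%, between 0% and 25%.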

Compound 4, largest response reached (reported as maximal response), in percent of the reference or control that the assay uses: 50%
Compound 4: the middle estimate sits 40 percentage points below what was measured, outside the stated range (above it).
By their numbers in this assay, from the lowest: compounds 2 and 3 (each within the scatter of the next); then compound 1; then compound 4.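

In this assay there is a number 35 percentage points higher from compound 1 to compound 4 (beyond the scatter) on exchanging 3,4-dichlorophenyl for 4-nitrophenyl on a saturated chain carbon bound to an aromatic nitrogen, so the response depends on the group at this position. The only earlier step concerned a carbonyl carbon elsewhere and moved nothing beyond the scatter, so this is the first single change shown to shift the maximal response. Nothing available accounts for the size of this step.

Still open, going by these compounds, is whether the rise follows the nitro group itself or the loss of the two chlorines. A plain phenyl or a 4-chlorophenyl at this place would separate the two.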